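A few compounds are considered here, and "the series" means these few. Any claim that something is new, unique, unknown or untested is made for them only; others in the source may bear on it.

Measured so far in an ADME assay on RAW264.7 cells (Mus musculus) for cytotoxicity, read by MTT assay, with a stated time of 24 h; a higher number here means that more compound is tolerated, a lower number that less compound is tolerated:
Compound 1 `CC/C=C\CC1C(=O)C=CC1CC(=O)OC` gives 140 uM.
Compound 2 `CC/C=C\C[C@H]1C(=O)C=C[C@H]1CC(=O)Oc1ccc(O)cc1` gives 49 uM.
Compound 3 `CC/C=C\C[C@H]1C(=O)C=C[C@H]1CC(=O)OC(C)c1ccccc1` gives 31 uM.

Compound 2 stands second highest of the three numbers. Its gap to compound 3 is within the scatter, so no order can be read between these two; compound 1 stands beyond the scatter above compound 2, the largest gap in the set. Compound 4 `CC/C=C\C[C@H]1C(=O)C=C[C@H]1CC(=O)OC1CCCCC1` differs from compound 2 in one place: cyclohexyl in place of 4-hydroxyphenyl on an oxygen next to a carbonyl group.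

All three measured compounds share the same core and differ only in the group on the oxygen next to the carbonyl group. Compound 1, with the smallest group, gives the highest number; compound 2 and compound 3, with larger groups, give numbers that sit within the scatter of each other. The cyclohexyl group entering in compound 4 is close in heavy-atom count to the 4-hydroxyphenyl group it replaces, as the counted difference shows. In this assay the step is therefore expected to be small, if anything slightly downward, and not beyond the scatter.

Compound 4 is expected to give 38 uM, with a range of 16 uM to 90 uM. The step this estimate means, a 1.3-fold lower number from compound 2 to compound 4 (0.11 log units; within the scatter), is expected to remain within the usual scatter.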

Compound 4, half-maximal toxic concentration: 31 uM
Compound 4: the middle estimate sits 1.2-fold (0.09 log units) above what was measured; the measured number falls inside the stated range.
By their numbers in this assay, from the lowest: compounds 3, 4 and 2 (each within the scatter of the next); then compound 1.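

Among these compounds, at the oxygen next to a carbonyl group, cyclohexyl in place of 4-hydroxyphenyl gives the first single-place comparison in this assay: a 1.6-fold lower number from compound 2 to compound 4 (0.20 log units; within the scatter). Within this one pair, replacing the aromatic ring with a non-aromatic one and going from one hydrogen-bond donor and one acceptor to none therefore produces no step beyond the scatter. No measured property bears on why the number holds across this change.

The ring type and the hydroxyl change together in this step, so their separate contributions remain unresolved, and an unsubstituted phenyl group at this place would be needed to tell them apart. Also open, as far as these compounds go, is whether an amine, a carboxylic acid or a longer carbon chain on this oxygen would give a step beyond the scatter.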